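The compounds below may be only part of what the source reports. "The series", "measured", "known", "first", "only" and "open" are said of these compounds alone.

Measured compounds:
compound 1 `Cc1ccc(S(=O)(=O)N2CCN(CCCn3c(=O)[nH]c4ccccc43)CC2)cc1`
compound 2 `O=c1[nH]c2ccccc2n1C/C=C/CN1CCN(C(c2ccccc2)c2ccccc2)CC1`
compound 3 `Cc1cc2ncn(CCCCN3CCN(C(c4ccccc4)c4ccccc4)CC3)c2cc1C`

In an assay on RPMI-8226 cells for antagonist activity at P2X purinoceptor 7 (Homo sapiens), read by calcium flux (a lower number here means a stronger inhibitor, a higher number a weaker inhibitor), compound 1 gives only a limit, > 10000 nM. Compound 2 likewise gives only a limit, > 10000 nM. Among the compounds with values here, compound 3 gives 770 nM, the only number among the three. The other two sit at the limit of > 10000 nM in this assay, at which 2 of the 3 values shown sit, so compound 3 stands alone as a measured inhibitor in this set.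

Compound 4 `COc1ccc2c(ccn2CCCCN2CCN(C(c3ccccc3)c3ccccc3)CC2)c1` differs from compound 3 in one place: 5-methoxy-1H-indol-1-yl in place of 5,6-dimethyl-1H-benzimidazol-1-yl on a saturated chain carbon, four bonds along the chain from an amine nitrogen in a ring. Within the data shown here, no measured pair shows the effect of this change, so the expectation rests on compound 3 alone. In this assay the expected step is small, a 1.3-fold higher number from compound 3 to compound 4 (0.11 log units; within the scatter), with no clear direction. Compound 4 is therefore estimated at 1000 nM, within a range from 300 nM to 5000 nM.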

Compound 4, half-maximal inhibitory concentration: > 10000 nM
Compound 4 ended at the assay's limit (the forecaster's own chance of this, stated with the estimate: 20%); middle value at least 10-fold (1.00 log units) from the limit.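

Replacing 5,6-dimethyl-1H-benzimidazol-1-yl with 5-methoxy-1H-indol-1-yl in this assay gives an at least 12-fold higher number from compound 3 to compound 4 (1.11 log units; beyond the scatter). The group at this place, on a saturated chain carbon, therefore matters to the read-out, even though both groups have 11 heavy atoms. The value of compound 4 is a limit, and compound 3 remains the only compound with a measured number: the limit of > 10000 nM in this assay, at which 3 of the 4 values shown sit.

The compounds shown do not separate the change in the ring nitrogen from the exchange of the two methyl groups for methoxy. 5,6-Dimethyl-1H-indol-1-yl or 5-methoxy-1H-benzimidazol-1-yl at this place would address that question.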